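This account rests on a few compounds, and the source may have more. Where it says the series, first, only, none or still open, it means among the compounds named here.

Compound 1 `COc1cc(NC(=O)Nc2cc(Nc3ccc(OC)c(C)c3)ncn2)cc(OC)c1`: 62%
Compound 2 `COc1ccc(Br)cc1Nc1cc(NC(=O)Nc2c(Cl)cccc2Cl)ncn1`: 69%
Compound 3 `CCc1ccc(Nc2cc(NC(=O)Nc3c(Cl)cccc3Cl)ncn2)cc1`: 70.1%

In a functional assay on PC-9 cells (Homo sapiens) for inhibition, read by MTT assay, with a stated time of 48 h, tested at 10 uM (on this read-out lower numbers stand for less inhibition and higher numbers for more inhibition at the one concentration tested (going by the name of the read-out)), compound 3 gives 70.1%, the top of the three numbers, but the step of a number 1.1 percentage points higher from compound 2 to compound 3 (within the scatter) is within the scatter, and compound 1 at 62% also lies within the scatter of compound 3. Compound 4 `COc1cc(Br)ccc1Nc1cc(NC(=O)Nc2c(Cl)cccc2Cl)ncn1` differs from compound 3 by 4-bromo-2-methoxyphenyl in place of 4-ethylphenyl on a nitrogen on an aromatic ring. Within the data shown here, the one measured step that bears on this exchange, a number 1.1 percentage points higher from compound 2 to compound 3 (within the scatter), replaced 5-bromo-2-methoxyphenyl with 4-ethylphenyl and changed nothing beyond the scatter; compound 4 brings a closely related group, 4-bromo-2-methoxyphenyl, back in place of 4-ethylphenyl. The step from compound 3 to compound 4 is therefore expected to stay within the scatter, a number 2.1 percentage points lower from compound 3 to compound 4 (within the scatter). Compound 4 is estimated to give 68%, most likely between 55% and 80%.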

Compound 4, a percentage reported as inhibition, at one concentration (the size of the read-out at that concentration, not a potency): 90.5%
Beside the measured number, compound 4's estimate is 22.5 percentage points below it; the measured number lies above the stated range.
By their numbers in this assay, from the lowest: compounds 1, 2 and 3 (each within the scatter of the next); then compound 4.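

In this assay, this place on the nitrogen responds to more than the kind of groups present: 5-bromo-2-methoxyphenyl and 4-bromo-2-methoxyphenyl carry the same atoms, yet exchanging them gives a number 21.5 percentage points higher from compound 2 to compound 4 (beyond the scatter) in this series. The earlier pair, 5-bromo-2-methoxyphenyl and 4-ethylphenyl, showed no such separation, whereas 4-bromo-2-methoxyphenyl in place of 4-ethylphenyl gives a number 20.4 percentage points higher from compound 3 to compound 4 (beyond the scatter) here. Nothing available explains this rise. The compounds shown leave open how much the bromine and the methoxy each contribute. They also leave open whether an amine or a carboxylic acid in place of the bromine would keep the higher number.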